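The compounds below may be only part of what the source reports. "The series", "measured", "known", "first", "only" and "open" are said of these compounds alone.

Compound 1 `Nc1cc(OCCNc2ccnc3cc(Cl)ccc23)nc(N)n1`: 174000 nM
Compound 2 `Nc1cc(OCCOCCNc2ccnc3cc(Cl)ccc23)nc(N)n1`: 250000 nM

In an ADME assay on CHO cells (Cricetulus griseus) for cytotoxicity, read by MTT assay, with a stated time of 48 h (a higher number here means a weaker inhibitor, a lower number a stronger inhibitor), compound 1 gives 174000 nM and compound 2 gives 250000 nM. These two numbers lie within the usual scatter of each other, so compound 1 stands level with compound 2, and neither can be ranked.

Compound 3 `CCC(COc1cc(N)nc(N)n1)Nc1ccnc2cc(Cl)ccc12` is built from compound 1 with one change: ethyl in place of hydrogen on a saturated chain carbon bound to a nitrogen on an aromatic ring and a saturated chain carbon.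

Within the data shown here, no measured pair shows what such a change does in this assay, so only a cautious expectation is possible. The expected step is a 1.3-fold lower number from compound 1 to compound 3 (0.13 log units; within the scatter), slightly toward a lower number and not beyond the scatter. For compound 3 the estimated value is 130000 nM, with an expected range from 50000 nM to 260000 nM.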

Compound 3, half-maximal inhibitory concentration in the CHO assay: 156000 nM
Beside the measured number, compound 3's estimate is 1.2-fold (0.08 log units) below it; the measured number falls inside the stated range.
By their numbers in the CHO assay, from the lowest: compounds 3, 1 and 2 (each within the scatter of the next).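

Ethyl in place of hydrogen on this saturated chain carbon gives the first reading of a change at this place, and in the CHO assay the result is a 1.1-fold lower number from compound 1 to compound 3 (0.05 log units; within the scatter), so the two compounds cannot be ranked. The same change separates the two compounds clearly in a physicochemical assay for solubility, read by HPLC, in phosphate buffer, with a stated time of 24 h, at 37 degrees C, at pH 5.5 (on this read-out lower numbers stand for lower solubility and higher numbers for higher solubility), where compound 1 gives 300 nM and compound 3 gives 40 nM, so compound 3 is the less soluble of the pair: the measured solubility of compound 1, 300 nM, and of compound 3, 40 nM, a 7.5-fold lower number (0.88 log units; beyond the scatter). At this position, then, ethyl leaves the cell reading level but carries a solubility cost.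

From the compounds shown here alone, whether a smaller methyl group or a hydroxymethyl group at the same carbon would reduce that cost stays open. So does whether an amine placed there would keep the reading in the CHO assay level while raising the reading in the physicochemical assay.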